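The compounds below may be only part of what the source reports. "The series", "measured", "known", "first", "only" and "open" are said of these compounds alone.

Measured compounds:
compound 1, `c1ccc(CNCc2nnc(-c3ccccc3-c3ccccc3)s2)cc1`, in a functional assay on the whole organism with Mus musculus as the target (a lower number here means that less compound is needed, a higher number that more compound is needed for the effect), compound 1 gives 29 mg/kg.
compound 2, `Cc1ccccc1NCc1nnc(-c2ccccc2-c2ccccc2)s1`, for which this assay reports only a limit: compound 2 gives > 200 mg/kg.

Compound 2 therefore stands at the edge of what this assay can report, and its number is a limit rather than a measured value (the limit of > 200 mg/kg in this assay, at which 1 of the 2 values shown sits). Among the compounds with values here, the single measured step, an at least 6.8-fold higher number from compound 1 to compound 2 (0.83 log units; beyond the scatter), shows that replacing benzyl with 2-methylphenyl on the amine nitrogen raised the dose needed by at least a modest amount.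

Compound 3, `CN(C)Cc1nnc(-c2ccccc2-c2ccccc2)s1`, differs from compound 2 by dimethylamino in place of (2-methylphenyl)amino on a saturated chain carbon bound to an aromatic carbon. Within the data shown here, no measured step covers this exact exchange; the only guide is that compound 2 sits at the limit after the change from benzyl, which the step from compound 1 indicates was unfavourable. A move away from the (2-methylphenyl)amino group is expected to bring the dose back below the limit, giving an estimated step of an at least 2.8-fold lower number from compound 2 to compound 3 (0.45 log units; beyond the scatter) in this assay. Compound 3 is accordingly expected to need 70 mg/kg, within a range from 20 mg/kg to 200 mg/kg.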

Compound 3, dose for half-maximal effect: 35 mg/kg
For compound 3 the middle estimate is 2.0-fold (0.30 log units) above the measured one; measured number inside the range.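

In this assay, the saturated chain carbon bound to an aromatic carbon accepts dimethylamino in place of benzylamino with no change beyond the scatter, a 1.2-fold higher number from compound 1 to compound 3 (0.08 log units; within the scatter), so the six-membered aromatic ring of the benzyl group is not needed for the effect in this pair. Dimethylamino in place of (2-methylphenyl)amino gives an at least 5.7-fold lower number from compound 2 to compound 3 (0.75 log units; beyond the scatter), which ties the loss seen with compound 2 to the (2-methylphenyl)amino group rather than to the shared core. The value of compound 2 is a limit and not a number, so the true size of that step stays unknown: the limit of > 200 mg/kg in this assay, at which 1 of the 3 values shown sits.

Going by these compounds, it remains open whether a cyclic amine such as piperidine or morpholine would match dimethylamino at this place, and whether a group without nitrogen, such as methoxy, would keep the effect. On these data alone, it is also open whether the loss with (2-methylphenyl)amino follows from its methyl group or from the aromatic ring itself, a question that plain phenylamino would help to separate.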